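From Fluoro to Chloro in a Small Compound Series

The compounds below may be only part of what the source reports. "The series", "measured", "known", "first", "only" and "open" are said of these compounds alone.

Three related compounds have numbers in a functional assay on L1210 cells (Mus musculus) for inhibition, read by MTT assay, with a stated time of 72 h; a lower number here means a stronger inhibitor, a higher number a weaker inhibitor. Compound 1 `COc1cc(NC(C)CCCNC(=O)NNC(=O)Nc2ccc(C(F)(F)F)cc2)c2ncccc2c1` gives 18000 nM, and compound 2 `COc1cc(NC(C)CCCNC(=O)Nc2ccc(F)cc2)c2ncccc2c1` gives 18000 nM, so the two stand level. Compound 3 `COc1cc(NC(C)CCCNC(=O)Nc2cc(C(F)(F)F)cc(C(F)(F)F)c2)c2ncccc2c1` gives 3500 nM, a lower number than the other two and one that lies beyond the usual scatter of repeat measurements. Compound 2 therefore sits with compound 1 at the weak end of this short set.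

Compound 4 `COc1cc(NC(C)CCCNC(=O)Nc2ccc(Cl)cc2)c2ncccc2c1` has not yet been measured. It differs from compound 2 in a single place: chloro in place of fluoro on an aromatic carbon. This is chloro in place of fluoro on an aromatic carbon, para to a large group.

Within the data shown here, no measured pair shows this exchange, so the expectation rests on thin ground. Among the measured compounds shown here, the only hint comes from compound 3, which carries trifluoromethyl groups on that ring instead of fluoro and gives 3500 nM. A small move toward a lower number seems most likely, and it may stay within the scatter. The estimated step is a 1.8-fold lower number from compound 2 to compound 4 (0.26 log units; within the scatter). For compound 4 the expected value in this assay is 10000 nM, with an estimated range from 4000 nM to 22000 nM.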

Compound 4, half-maximal inhibitory concentration: 19000 nM
Compound 4: middle estimate off by 1.9-fold (0.28 log units), on the low side; low and high end bracket the measured number.
By their numbers in this assay, from the lowest: compound 3; then compounds 1, 2 and 4 (each within the scatter of the next).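

In this assay, putting chloro in place of fluoro on the aromatic carbon, para to a large group, gives a 1.1-fold higher number from compound 2 to compound 4 (0.02 log units; within the scatter) and so makes no measurable difference. Among these compounds, this is the first pair in the set that differs in this one place only, which allows a direct reading: with the rest of the molecule unchanged, 4-fluorophenyl and 4-chlorophenyl cannot be told apart in this test. Nothing shown here gives a measured explanation for this result.

As far as these compounds go, whether this position tolerates other changes as well remains open, since this single exchange swaps only one halogen for another, and a methoxy group, an amine or a carboxylic acid on the same carbon could behave quite differently. Compound 3 also differs from compound 2 in more than one place, so the changes behind its separate standing cannot be pulled apart, and neither the effect of a single trifluoromethyl group at this position nor that of a longer chain can be read from these compounds.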